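Dropping one methoxy from the dimethoxy aryl urea

The source may report more compounds than this note shows. Statements on the series, on what has been measured and on what is new or still open speak of the compounds shown alone.

Compound 1 `COc1ccc(NC(=O)Nc2cc(C)nc3ccccc23)cc1OC` is examined in an ADME assay on BJ cells (Homo sapiens) for cytotoxicity, with a stated time of 72 h; on this read-out higher numbers stand for an effect only at larger amounts of compound and lower numbers for an effect already at smaller amounts. In this assay compound 1 gives only a limit, > 25000 nM. The closest measured neighbour is compound 2 `COc1cccc(NC(=O)Nc2cc(C)nc3ccccc23)c1`, which in this assay gives 27000 nM. The step that the limit leaves unreadable from compound 1 to compound 2 has no readable size. Compound 3 `Cc1cc(NC(=O)Nc2ccccc2F)c2ccccc2n1` in this assay likewise gives only a limit, > 25000 nM. Compound 1 thus stands at the limit of > 25000 nM in this assay, at which 2 of the 3 values shown sit, where most of the set stands, and no reading beyond that limit is available for it.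

Compound 4 `COc1ccc(NC(=O)Nc2cc(C)nc3ccccc23)cc1` is not yet measured. Its difference from compound 1 is the following: hydrogen in place of methoxy on an aromatic carbon. The only measured step that bears on this change is the one that the limit leaves unreadable, and no step beyond the scatter is shown anywhere in the set. The change is therefore expected to leave compound 4 close to the limit, with an estimated step that the limit leaves unreadable from compound 1 to compound 4. Compound 4 is expected at about 30000 nM, within 14000 nM to 65000 nM, most probably reported again as a limit.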

Compound 4, half-maximal effective concentration: > 25000 nM
Compound 4 ended at the assay's limit (the forecaster's own chance of this, stated with the estimate: 65%); the middle value does not contradict the limit.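

Compound 1 and compound 4 each give only a limit in this assay, so no new step can be read between them: the limit of > 25000 nM in this assay, at which 3 of the 4 values shown sit.

The compounds shown leave open whether hydrogen in place of methoxy on an aromatic carbon shifts this read-out at all.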